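The source may hold more compounds than are shown below. What is called first, only, known or untested is meant among the compounds shown, and "the series" means these compounds.

Compound 1 `Cc1cccc2c(NCc3ccco3)nc(NC(C)C)nc12` carries a methyl on its core. In a physicochemical assay for solubility, at pH 7.4 (on this read-out higher numbers stand for higher solubility and lower numbers for lower solubility), compound 1 gives <= 20000 nM, which is a limit of the assay rather than a number. Compound 3 `COc1cccc2c(NCc3ccco3)nc(NC(C)C)nc12` has the change (methoxy in place of methyl on an aromatic carbon). In this assay compound 3 gives <= 20000 nM, again only a limit. The step that the two limits leave unreadable from compound 1 to compound 3 therefore cannot be read, since both values sit at the limit of <= 20000 nM in this assay, at which 2 of the 3 values shown sit. Compound 2 `Cc1cccc2nc(NC(C)C)nc(NCc3ccco3)c12` is built from the same atoms joined differently; the difference between the two cores is not broken down here. In this assay compound 2 gives <= 10000 nM, a limit as well, the line (the limit of <= 10000 nM in this assay, at which 1 of the 3 values shown sits). Compound 4 `COc1cccc2nc(NC(C)C)nc(NCc3ccco3)c12` makes the same change, (methoxy in place of methyl on an aromatic carbon). Because the earlier step that the two limits leave unreadable from compound 1 to compound 3 gives no readable size, the expected step that the limit leaves unreadable from compound 2 to compound 4 for compound 4 is small. Compound 4 is estimated at 8000 nM in this assay, expected between 2000 nM and 20000 nM.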

Compound 4, solubility: <= 20000 nM
Compound 4 ended at the assay's limit; the forecaster's own chance of this, stated with the estimate: 70%; the middle value is on the limit's open side.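

Compound 2 and compound 4 both give only limits in this assay, so the step between them cannot be read. The compounds shown leave open whether methoxy in place of methyl changes solubility at all.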